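From Cyclopropyl to (Methoxycarbonyl)methyl on the Ring Nitrogen

The source may report more compounds than this note shows. Statements on the series, on what has been measured and on what is new or still open speak of the compounds shown alone.

Compound 1 `O=c1c(S(=O)(=O)c2ccc(F)cc2F)cc2cnc(Nc3ccc4[nH]ccc4c3)nc2n1C1CC1` gives 500 nM in a functional assay on K562 cells (Homo sapiens) for inhibition, read by trypan blue exclusion, with a stated time of 72 h (on this read-out higher numbers stand for weaker inhibition and lower numbers for stronger inhibition), the lowest of the three numbers measured. Compound 2 `Cc1ccc(S(=O)(=O)c2cc3cnc(Nc4ccc5[nH]ccc5c4)nc3n(C)c2=O)cc1` gives 750 nM, within the scatter of compound 1, while compound 3 `Cc1ccc(S(=O)(=O)c2cc3cnc(Nc4cnc5[nH]ccc5c4)nc3n(C)c2=O)cc1` gives 15000 nM. For the measured compounds named here, the only single-point step known, a 20-fold higher number from compound 2 to compound 3 (1.30 log units; beyond the scatter), concerns the group on the exocyclic nitrogen, not the ring nitrogen. Compound 4 `COC(=O)Cn1c(=O)c(S(=O)(=O)c2ccc(F)cc2F)cc2cnc(Nc3ccc4[nH]ccc4c3)nc21` differs from compound 1 by (methoxycarbonyl)methyl in place of cyclopropyl on an aromatic nitrogen. Going by the values given here, no measured step addresses this change; compounds 1 and 2, which carry different groups at that nitrogen among other differences, show numbers within the scatter of each other. Compound 4 is therefore expected to stay close to compound 1, with a 1.6-fold higher number from compound 1 to compound 4 (0.20 log units; within the scatter) as the anticipated step. The estimate for compound 4 is 800 nM, ranging from 250 nM to 3000 nM.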

Compound 4, half-maximal inhibitory concentration: 5000 nM
Compound 4: the middle estimate sits 6.3-fold (0.80 log units) below what was measured, and the stated range ends below it.
By their numbers in this assay, from the lowest: compounds 1 and 2 (each within the scatter of the next); then compound 4; then compound 3.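

In this assay, putting (methoxycarbonyl)methyl in place of cyclopropyl on the aromatic nitrogen gives a 10-fold higher number from compound 1 to compound 4 (1.00 log units; beyond the scatter), so the group held at this nitrogen does affect the result. This is the first step shown that changes this position alone, which the earlier compounds could not provide. Nothing available explains why the number rises here. From the compounds shown here alone, whether the rise follows from the loss of the cyclopropyl ring or from the arrival of the ester remains open. A plain ethyl group or a carboxylic acid at this nitrogen would help separate these two readings.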